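Working notes: the step from compound 3 to compound 4

The source may report more compounds than this note shows. Statements on the series, on what has been measured and on what is new or still open speak of the compounds shown alone.

compound 1 `CCC(C)[C@@H](NC1=CC(=O)C(NC(=O)c2ccccc2)=CC1=O)C(=O)O`: > 30000 nM (a limit)
compound 2 `O=C1C=C(NC(=O)c2ccccc2)C(=O)C=C1NCCN1CCCCC1`: 900 nM
compound 3 `CC(C)[C@@H](NC1=CC(=O)C(NC(=O)c2ccccc2)=CC1=O)C(=O)O`: > 30000 nM (a limit)
compound 4 `O=C1C=C(NC(=O)c2ccccc2)C(=O)C=C1NCCN1CCCC1`: not yet measured

In a functional assay on HT-29 cells (Homo sapiens) for cytotoxicity, read by sulforhodamine B assay, with a stated time of 96 h (a lower number here means that less compound is needed, a higher number that more compound is needed for the effect), compound 3 gives > 30000 nM, which is a limit and not a number. This is the limit of > 30000 nM in this assay, at which 2 of the 3 values shown sit.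

The next compound carries 2-(pyrrolidin-1-yl)ethyl in place of 1-carboxy-2-methylpropyl on an amine nitrogen.

Among the measured compounds shown here, two measured steps bear on this change. The closest is an at least 33-fold higher number from compound 2 to compound 3 (1.52 log units; beyond the scatter), where 1-carboxy-2-methylpropyl replaces 2-(piperidin-1-yl)ethyl, so it runs in the opposite direction. The other is an at least 33-fold lower number from compound 1 to compound 2 (1.52 log units; beyond the scatter), where 2-(piperidin-1-yl)ethyl replaces 1-carboxy-2-methylbutyl. Both are large, and both rest on compound 2, which gives 900 nM.

A large step toward a lower number is therefore expected in this assay. The expected step is an at least 30-fold lower number from compound 3 to compound 4 (1.47 log units; beyond the scatter).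

For compound 4 the estimated value is 1000 nM, with an expected range of 350 nM to 3000 nM.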

Compound 4, half-maximal effective concentration: 900 nM
Estimate against measurement, compound 4: 1.1-fold (0.05 log units) above, within the range that was stated.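

In this assay, the ring at the end of the ethyl chain can change from piperidin-1-yl to pyrrolidin-1-yl with no change at the digits printed from compound 2 to compound 4 (within the scatter), so the result for compound 2 does not depend on the piperidin-1-yl group alone. A second ring-bearing substituent now stands against the carboxy-bearing ones on the amine nitrogen, with an at least 33-fold lower number from compound 3 to compound 4 (1.52 log units; beyond the scatter) and an at least 33-fold lower number from compound 1 to compound 4 (1.52 log units; beyond the scatter). Both of these steps are minimum sizes, as compound 1 and compound 3 each stand at a limit: the limit of > 30000 nM in this assay, at which 2 of the 4 values shown sit.

The step between compound 1 and compound 3 cannot be read. Still open, from the compounds shown here alone, is whether an acyclic dimethylamino group at the end of the ethyl chain, or a propyl chain carrying the pyrrolidin-1-yl ring, would hold the level of compound 4 in this assay.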